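The source may hold more compounds than are shown below. What is called first, only, known or untested is meant among the compounds shown, and "the series" means these compounds.

Measured so far, in a functional assay on synaptosomes from brain (strain Sprague-Dawley) for agonist activity at Nicotinic acetylcholine receptor alpha6/alpha3/beta2/beta3 (Rattus norvegicus); on this read-out lower numbers stand for an effect already at smaller amounts and higher numbers for an effect only at larger amounts of compound:

Compound 1 `C1=C(c2cncc(Oc3ccccc3)c2)CC2CNCC1C2` — in this assay compound 1 gives 718 nM
Compound 2 `CC(C)Oc1cncc(C2=CC3CNCC(C2)C3)c1` — in this assay compound 2 gives 1090 nM

Among the compounds with values here, compound 2 has the higher of the two numbers, but the only step that reaches it, a 1.5-fold higher number from compound 1 to compound 2 (0.18 log units; within the scatter), lies within the scatter, so the two values cannot be told apart; compound 2 and compound 1 behave alike on this read-out.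

Compound 3 `CC(C)Oc1cncc(C2=CC3CC(C2)CN(C)C3)c1` has not been measured. It differs from compound 2 in one place: methyl in place of hydrogen on an amine nitrogen in a ring, that is, on an amine nitrogen in a ring of a six-membered non-aromatic ring with one nitrogen, part of a bridged system of two rings. Within the data shown here, the one measured step, from compound 1 to compound 2, changes an aryl ether and leaves this amine untouched, so no measured step bears on the change from compound 2 to compound 3; nothing in the present numbers tells how this amine tolerates a methyl.

With no guide, a mild shift toward a higher number is expected for compound 3, a 1.8-fold higher number from compound 2 to compound 3 (0.26 log units; within the scatter), with a wide range. The estimate for compound 3 is 2000 nM, from 700 nM to 6000 nM.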

Compound 3, half-maximal effective concentration: 879 nM
Compound 3: the middle estimate sits 2.3-fold (0.36 log units) above what was measured; the measured number falls inside the stated range.
By their numbers in this assay, from the lowest: compounds 1, 3 and 2 (each within the scatter of the next).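

In this assay, the amine nitrogen in the ring now has a measured change of its own, and the step is a 1.2-fold lower number from compound 2 to compound 3 (0.09 log units; within the scatter). Within the data shown here, the earlier pair changed only the group on the oxygen, so this is the first reading at this nitrogen, and it shows that methyl in place of hydrogen there leaves compound 3 and compound 2 indistinguishable on this read-out, which means that, with isopropyl on the oxygen, the hydrogen on this nitrogen is not needed for the value to stay within the scatter. No measurement at hand offers a reason for this outcome.

Going by these compounds, how far this tolerance extends on the same nitrogen stays open, since a single methyl says nothing about what an ethyl, a benzyl or a longer chain would do, or about an acetyl, which would turn the amine into an amide. On these data alone, it is also open whether the methyl gives the same result with the phenyl of compound 1 on the oxygen, as the change has been read only with isopropyl there.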